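Swapping the Ring-Nitrogen Substituent in a Thiophene Amide Series

This account rests on a few compounds, and the source may have more. Where it says the series, first, only, none or still open, it means among the compounds named here.

Measured compounds:
- compound 1, `NC(=O)c1c(NC(=O)c2ccc(C(F)(F)F)cc2)sc2c1CCN(Cc1ccc(Cl)cc1Cl)C2`: 14900 nM
- compound 2, `Cc1ccc(C(=O)Nc2sc3c(c2C(N)=O)CCN(Cc2ccc(Cl)cc2Cl)C3)cc1`: 19900 nM
- compound 3, `NC(=O)c1c(NC(=O)c2cccc([N+](=O)[O-])c2)sc2c1CCN(Cc1ccc(Cl)cc1Cl)C2`: 19800 nM

All three were tested in a functional assay on HL-60 cells (Homo sapiens) for antiproliferative activity, with a stated time of 24 h; on this read-out lower numbers stand for stronger inhibition and higher numbers for weaker inhibition. Compound 2 gives the highest number of the three, but its neighbours sit close: the step of a 1.3-fold higher number from compound 1 to compound 2 (0.13 log units; within the scatter) and the step of a 1.0-fold lower number from compound 2 to compound 3 (0.00 log units; within the scatter) both stay within the usual scatter, so the three compounds cannot be ranked against one another.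

Compound 4, `Cc1ccc(C(=O)Nc2sc3c(c2C(N)=O)CCN(C(=O)Nc2ccccc2Cl)C3)cc1`, has not yet been measured. It differs from compound 2 in one place: (2-chlorophenyl)carbamoyl in place of 2,4-dichlorobenzyl on an amine nitrogen in a ring. For the measured compounds named here, every measured step so far changes only the aromatic group attached to the carbonyl carbon, leaving the 2,4-dichlorobenzyl untouched. Those steps, a 1.3-fold higher number from compound 1 to compound 3 (0.12 log units; within the scatter) included, were all small. None of them speaks directly to the group on the ring nitrogen, so the data give no guide to the direction of this change, and the three measured compounds cluster in a narrow band.

The working expectation is therefore a number near that of compound 2, with a wide margin. Compound 4 is estimated to give about 25000 nM, within a range from 5000 nM to 100000 nM. This corresponds to an expected step of a 1.3-fold higher number from compound 2 to compound 4 (0.10 log units; within the scatter).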

Compound 4, half-maximal inhibitory concentration: 14600 nM
Compound 4: the middle estimate sits 1.7-fold (0.23 log units) above what was measured; the measured number falls inside the stated range.
By their numbers in this assay, from the lowest: compounds 4, 1, 3 and 2 (each within the scatter of the next).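

For the compounds shown here, compound 2 and compound 4 give the first look at the amine nitrogen in the ring, since every earlier step changed only the aromatic group on the carbonyl carbon. In this assay the exchange of 2,4-dichlorobenzyl for (2-chlorophenyl)carbamoyl gives a 1.4-fold lower number from compound 2 to compound 4 (0.13 log units; within the scatter) and so the two numbers cannot be told apart, even though the entering group adds a carbonyl, 1 hydrogen-bond donor and 1 hydrogen-bond acceptor that the leaving group lacks. This position therefore accepts at least this one quite different group without a readable shift in the number, and nothing available here bears on why that is so.

As far as these compounds go, with a single exchange at this nitrogen and all four numbers in one narrow band, it remains open whether any group on the ring nitrogen can move the number beyond the scatter, for instance a plain hydrogen, a methyl or an acetyl. Also open, from the compounds shown here alone, is whether the same (2-chlorophenyl)carbamoyl group behaves alike when the carbonyl carbon carries 4-(trifluoromethyl)phenyl or 3-nitrophenyl instead of 4-methylphenyl.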